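Oxime ether chain truncation on the quinone series

The source may report more compounds than this note shows. Statements on the series, on what has been measured and on what is new or still open speak of the compounds shown alone.

Measured so far:
compound 1 `CCCCCCCO/N=C(\CCCCCC)c1cc(OC)c2c(c1OC)C(=O)C=CC2=O`, a functional assay on L1210 cells (Mus musculus) for antiproliferative activity (a lower number here means that less compound is needed, a higher number that more compound is needed for the effect), 0.162 ug/mL
compound 2 `CCCCCC/C(=N\OCCCCC)c1cc(OC)c2c(c1OC)C(=O)C=CC2=O`, this assay 0.224 ug/mL

Compound 2 stands beside compound 1 on the numbers in hand: the step of a 1.4-fold higher number from compound 1 to compound 2 (0.14 log units; within the scatter) is within the scatter, so the two values cannot be separated. Compound 3 `CCCCCC/C(=N\OC)c1cc(OC)c2c(c1OC)C(=O)C=CC2=O` is not yet measured. Its change from compound 2 is hydrogen in place of butyl on a saturated chain carbon bound to an oxygen, the same kind of chain shortening as the step from compound 1 to compound 2, but cut further. Going by the values given here, only that one step bears on it, and it was flat. With no other information, the expectation for compound 3 is a step of a 1.3-fold higher number from compound 2 to compound 3 (0.13 log units; within the scatter), nominally toward a higher number but likely still within the scatter. Compound 3 is therefore estimated at 0.3 ug/mL, with a range from 0.12 ug/mL to 0.75 ug/mL.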

Compound 3, concentration for half-maximal effect: 0.192 ug/mL
Estimate against measurement, compound 3: 1.6-fold (0.19 log units) above; the range from low to high includes it.
By their numbers in this assay, from the lowest: compounds 1, 3 and 2 (each within the scatter of the next).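

In this assay, replacing butyl with hydrogen on the saturated chain carbon bound to an oxygen, which turns pentyloxy into methoxy, gives a 1.2-fold lower number from compound 2 to compound 3 (0.07 log units; within the scatter). The deeper cut, hydrogen in place of hexyl at that same carbon, gives a 1.2-fold higher number from compound 1 to compound 3 (0.07 log units; within the scatter), so even the methoxy end of the series cannot be separated from the two longer chains, a wider span than the earlier small trim covered. No measurement on hand bears on why this chain length leaves the number unresolved.

Going by these compounds alone, still open is whether the same flat reading holds for a chain longer than the one in compound 1, or for a chain ending in an amine or a carboxylic acid. On these data alone, the hexyl chain on the other side of the oxime is shared by all three compounds, so any role it has in this assay remains unknown.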